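Swapping the N-aryl group on a shared core

The compounds below may be only part of what the source reports. "The series", "measured", "known", "first", "only" and "open" are said of these compounds alone.

Measured compounds:
compound 1, `COc1cc2c(Oc3ccc(NC(=O)c4nn(-c5ccccc5C(F)(F)F)c(=O)cc4C)cc3F)ccnc2cc1OCCCN1CCCC1`: 100 nM
compound 2, `COc1cc2c(Oc3ccc(NC(=O)c4nn(-c5ccccc5C(F)(F)F)c(=O)cc4C)cc3F)ccnc2cc1OCCCN1CCC(C)CC1`: 60 nM

Of the compounds shown here, two have been measured in a functional assay on MKN-45 cells (Homo sapiens) for inhibition, read by MTT assay, with a stated time of 72 h; a lower number here means a stronger inhibitor, a higher number a weaker inhibitor. Compound 1 `COc1cc2c(Oc3ccc(NC(=O)c4nn(-c5ccccc5C(F)(F)F)c(=O)cc4C)cc3F)ccnc2cc1OCCCN1CCCC1` gives 100 nM, and compound 2 `COc1cc2c(Oc3ccc(NC(=O)c4nn(-c5ccccc5C(F)(F)F)c(=O)cc4C)cc3F)ccnc2cc1OCCCN1CCC(C)CC1` gives 60 nM. For the measured compounds named here, compound 1 has the numerically larger of the two results, but its only neighbour is compound 2, and the step of a 1.7-fold lower number from compound 1 to compound 2 (0.22 log units; within the scatter) lies within the scatter, so the two compounds are not distinguished by these numbers.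

Compound 3 `COc1cc2c(Oc3ccc(NC(=O)c4nn(-c5ccc(Cl)cc5)c(=O)cc4C)cc3F)ccnc2cc1OCCCN1CCCC1` has not yet been measured. It differs from compound 1 in a single place: 4-chlorophenyl in place of 2-(trifluoromethyl)phenyl on an aromatic nitrogen. Going by the values given here, no measured step touches this position. Among the compounds with values here, the one step available, a 1.7-fold lower number from compound 1 to compound 2 (0.22 log units; within the scatter), alters the amine at the end of the chain instead and is itself within the scatter, so it says nothing about the aryl group on the aromatic nitrogen. Within the data shown here, with no relevant precedent, the expected outcome is a step of no size beyond the scatter. Compound 3 is therefore estimated at 110 nM in this assay, with a range from 35 nM to 350 nM. The expected step is a 1.1-fold higher number from compound 1 to compound 3 (0.04 log units; within the scatter), and the actual measurement must decide.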

Compound 3, half-maximal inhibitory concentration: 150 nM
Estimate against measurement, compound 3: 1.4-fold (0.13 log units) below, within the range that was stated.
By their numbers in this assay, from the lowest: compounds 2, 1 and 3 (each within the scatter of the next, the first and the last beyond it).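

For the compounds shown here, this is the first measured change to the aryl group on the aromatic nitrogen: in this assay, 4-chlorophenyl in place of 2-(trifluoromethyl)phenyl gives a 1.5-fold higher number from compound 1 to compound 3 (0.18 log units; within the scatter). The exchange alters both the substituent and where it sits on the phenyl ring, and it takes the group from 10 heavy atoms to 7, yet this step does not separate compound 3 from compound 1, so this one pair shows that the two aryl groups can be exchanged without a difference these numbers can resolve. No independent evidence bears on this result, so nothing can be said about what lies behind it.

Since the substituent and its place on the ring change together here, the effect of each remains unresolved; 2-chlorophenyl and 4-(trifluoromethyl)phenyl would separate the two. Also open, as far as these compounds go, is whether a step beyond the scatter appears with more distant groups on this nitrogen, such as an unsubstituted phenyl, a pyridyl ring or a simple methyl, and whether 4-chlorophenyl behaves the same alongside the 4-methylpiperidin-1-yl chain end.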